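A Flipped Ring Stereocentre in a Weak Antiproliferative Pair

The source may hold more compounds than are shown below. What is called first, only, known or untested is meant among the compounds shown, and "the series" means these compounds.

In a functional assay on U2OS cells (Homo sapiens) for antiproliferative activity, read by MTT assay, with a stated time of 72 h (a lower number here means a stronger inhibitor, a higher number a weaker inhibitor), compound 1 `O=C(C1=C(Nc2ccc(I)cc2)C(=O)N(CCCn2ccnc2)C1c1ccc(Br)cc1)c1ccccc1` gives 12000 nM. Compound 2 `C[C@@H](NC1=C(C(=O)c2ccccc2)[C@@H](c2ccc(Br)cc2)N(CCCn2ccnc2)C1=O)c1ccccc1` gives 28100 nM, the highest of the two numbers shown, with compound 1 the nearer at a lower value that lies beyond the scatter. Compound 3 `C[C@@H](NC1=C(C(=O)c2ccccc2)[C@H](c2ccc(Br)cc2)N(CCCn2ccnc2)C1=O)c1ccccc1` keeps every atom and bond of compound 2 and changes only configuration: the two compounds have the same atoms and bonds and differ only in configuration as drawn: 1 of 2 stereo elements differ; a stereocentre at a saturated ring carbon is drawn R in compound 2 and S in compound 3. Among the measured compounds shown here, no measured pair here tests such a change, so the expected step is modest, a 1.3-fold lower number from compound 2 to compound 3 (0.11 log units; within the scatter), with no direction that can be called beyond the scatter. Compound 3 is therefore estimated at 22000 nM, with a range from 7000 nM to 60000 nM.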

Compound 3, half-maximal inhibitory concentration: 30800 nM
The estimate for compound 3 lay 1.4-fold (0.15 log units) below the measured number, within the range that was stated.
By their numbers in this assay, from the lowest: compound 1; then compounds 2 and 3 (each within the scatter of the next).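

In this assay the stereocentre at the saturated ring carbon receives its first direct test, with a 1.1-fold higher number from compound 2 to compound 3 (0.04 log units; within the scatter). With this pair, drawing that carbon R or S makes no difference that can be read beyond the scatter, and the comparison isolates a single change: the fact that compounds 2 and 3 differ only in the configuration as drawn.

The compounds shown leave open how the other stereo element behaves, since it is drawn the same in compound 2 and compound 3. They also leave open whether this insensitivity to configuration would hold with an amine or a carboxylic acid in place of the bromine.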